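The source may hold more compounds than are shown below. What is called first, only, known or untested is meant among the compounds shown, and "the series" means these compounds.

In a functional assay on HeLa cells (Homo sapiens) for inhibition, read by MTT assay, with a stated time of 72 h (on this read-out higher numbers stand for weaker inhibition and lower numbers for stronger inhibition), compound 1 `Cc1noc(C)c1-c1cnc(N)c(Oc2ccc(C(=O)NC3CCCC3)cc2)n1` gives 9970 nM, the second highest of the three numbers recorded here. Compound 2 `Cc1noc(C)c1-c1cnc(N)c(Oc2ccc(C(=O)Nc3ccccc3)cc2)n1` gives 10500 nM in this assay, and compound 3 `Cc1noc(C)c1-c1cnc(N)c(Oc2ccc(C(=O)Nc3cccc(Cl)c3)cc2)n1` gives 1340 nM. The step of a 1.1-fold higher number from compound 1 to compound 2 (0.02 log units; within the scatter) lies within the scatter, so swapping the cyclopentyl for a plain phenyl left inhibition essentially unchanged. The step of a 7.4-fold lower number from compound 1 to compound 3 (0.87 log units; beyond the scatter) and the step of a 7.8-fold lower number from compound 2 to compound 3 (0.89 log units; beyond the scatter) both run toward stronger inhibition, and both are modest but beyond the scatter, once a chlorine sits on that phenyl ring.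

Compound 4 `Cc1noc(C)c1-c1cnc(N)c(Oc2ccc(C(=O)Nc3cc(Cl)ccn3)cc2)n1` differs from compound 1 as follows: 4-chloropyridin-2-yl in place of cyclopentyl on an amide-type nitrogen. Going by the values given here, the entering group is again an aromatic ring carrying a chlorine, as in compound 3, but this ring also holds a nitrogen, and no measured step tells what that nitrogen does. The closest measured guide is therefore compound 3. Because compound 3 gives 1340 nM, compound 4 is expected to come in with a step of about a 4.0-fold lower number from compound 1 to compound 4 (0.60 log units; beyond the scatter) toward stronger inhibition, with some doubt added by the untested nitrogen. The estimate for compound 4 in this assay is 2500 nM, with a range from 800 nM to 8000 nM.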

Compound 4, half-maximal inhibitory concentration: 37900 nM
Estimate against measurement, compound 4: 15-fold (1.18 log units) below; measured number outside the range, above it.
By their numbers in this assay, from the lowest: compound 3; then compounds 1 and 2 (each within the scatter of the next); then compound 4.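

At this amide-type nitrogen, a chlorine on an aromatic ring does not by itself bring stronger inhibition: replacing 3-chlorophenyl with 4-chloropyridin-2-yl gives a 28-fold higher number from compound 3 to compound 4 (1.45 log units; beyond the scatter) and reverses the gain seen with compound 3. The same group also falls behind both rings without chlorine, with a 3.6-fold higher number from compound 2 to compound 4 (0.56 log units; beyond the scatter) against the phenyl and a 3.8-fold higher number from compound 1 to compound 4 (0.58 log units; beyond the scatter) against the cyclopentyl, so this position can move inhibition in either direction beyond the scatter. Nothing available here explains why this ring behaves so differently from the 3-chlorophenyl ring.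

Compound 3 and compound 4 differ in two features at once, the ring nitrogen and the numbered place of the chlorine, so this step cannot assign the loss to either one. A plain pyridin-2-yl or a 4-chlorophenyl on the same nitrogen would help to separate the two, and an amine or a carboxylic acid on the phenyl ring in place of the chlorine would show whether the gain in compound 3 is particular to chlorine.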